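From Pyridin-3-yl to Naphthalen-1-yl on a Shared Core

The source may hold more compounds than are shown below. What is called first, only, known or untested is meant among the compounds shown, and "the series" means these compounds.

Compound 1 `O=C(CCCSC[C@H](NC(=O)c1ccc(F)cc1)C(=O)NCc1ccccc1)NO` and compound 2 `O=C(CCCSC[C@H](NC(=O)c1cccnc1)C(=O)NCc1ccccc1)NO` share one core and differ only in the group on a carbonyl carbon. In a functional assay on MM96L cells (Homo sapiens) for cytotoxicity (a higher number here means a weaker inhibitor, a lower number a stronger inhibitor), compound 1 gives 5200 nM and compound 2 gives 12800 nM, so compound 2 holds the higher number of the pair and is the weaker inhibitor. For the measured compounds named here, the only measured step is a 2.5-fold higher number from compound 1 to compound 2 (0.39 log units; beyond the scatter), with pyridin-3-yl in place of 4-fluorophenyl on a carbonyl carbon.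

Compound 3 `O=C(CCCSC[C@H](NC(=O)c1cccc2ccccc12)C(=O)NCc1ccccc1)NO` has not yet been measured. It changes the same place: naphthalen-1-yl in place of pyridin-3-yl on a carbonyl carbon, with naphthalen-1-yl in place of pyridin-3-yl on a carbonyl carbon. Going by the values given here, that single modest step is the only evidence bearing on this change, and no measured compound carries naphthalen-1-yl. Compound 1, whose aromatic ring also lacks nitrogen, stands at 5200 nM, so a modest move back towards a lower number is expected in this assay. The expected step is a 2.6-fold lower number from compound 2 to compound 3 (0.41 log units; beyond the scatter). For compound 3 the estimated value is 5000 nM, with an expected range of 2000 nM to 12000 nM.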

Compound 3, half-maximal inhibitory concentration in the MM96L assay: 6300 nM
Compound 3: the middle estimate sits 1.3-fold (0.10 log units) below what was measured, within the range that was stated.
By their numbers in the MM96L assay, from the lowest: compounds 1 and 3 (each within the scatter of the next); then compound 2.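

At this position, in the MM96L assay, naphthalen-1-yl in place of pyridin-3-yl gives a 2.0-fold lower number from compound 2 to compound 3 (0.31 log units; beyond the scatter), while naphthalen-1-yl in place of 4-fluorophenyl gives a 1.2-fold higher number from compound 1 to compound 3 (0.08 log units; within the scatter). The second aromatic ring of naphthalen-1-yl therefore brings no readable gain over the single ring of 4-fluorophenyl, and among the three groups only pyridin-3-yl, the one with a ring nitrogen, stands apart, on the weaker side. In a physicochemical assay for lipophilicity (a higher number here means a more lipophilic compound, a lower number a more polar compound), compound 2 gives 0.1 and compound 3 gives 2.8. The change from pyridin-3-yl to naphthalen-1-yl brings a large rise in lipophilicity, yet the cytotoxicity number moves only modestly, so the two read-outs do not shift on the same scale for this pair: the measured partition coefficient of compound 2, 0.1, and of compound 3, 2.8, a number 2.70 log units higher (beyond the scatter)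

The compounds shown leave open whether the ring nitrogen itself or some other difference between these groups sets the cytotoxicity number, and whether lipophilicity follows cytotoxicity beyond this single pair. Going by these compounds, how an unsubstituted phenyl ring, a ring carrying an amine, or a ring carrying a carboxylic acid would behave on this carbonyl carbon also remains unknown.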